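This account rests on a few compounds, and the source may have more. Where it says the series, first, only, none or still open, it means among the compounds named here.

Measured in a functional assay on A549 cells (Homo sapiens) for cytotoxicity, read by MTT assay, with a stated time of 72 h; on this read-out lower numbers stand for stronger inhibition and higher numbers for weaker inhibition:
compound 1 `O=S(=O)(c1ccccc1)c1nc2ccccc2nc1N1CCc2ccccc2C1` gives 19800 nM.
compound 2 `Cc1ccc(S(=O)(=O)c2nc3ccccc3nc2N2CCc3ccccc3C2)cc1` reaches only the assay limit, > 50000 nM.
compound 3 `O=S(=O)(c1ccccc1)c1nc2ccccc2nc1N1CCCC(O)C1` gives 310 nM.

Compound 3 stands lowest of the two numbers, with compound 1 well above it; how the two cores differ is not broken down here. Compound 4 `Cc1ccc(S(=O)(=O)c2nc3ccccc3nc2N2CCCC(O)C2)cc1` has not been measured in this assay. It differs from compound 3 by methyl in place of hydrogen on an aromatic carbon. The same change, (methyl in place of hydrogen on an aromatic carbon), gave an at least 2.5-fold higher number from compound 1 to compound 2 (0.40 log units; beyond the scatter), a step whose size is set by the limit of > 50000 nM in this assay, at which 1 of the 3 values shown sits, rather than by a number, so only its lower bound is known. The place of the change is the same in both pairs. For compound 4 a similar loss is expected; the step from compound 3 to compound 4 is estimated as a 4.8-fold higher number from compound 3 to compound 4 (0.68 log units; beyond the scatter), resting on an at least 2.5-fold higher number from compound 1 to compound 2 (0.40 log units; beyond the scatter). Compound 4 is therefore expected to give 1500 nM in this assay, most likely between 400 nM and 8000 nM.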

Compound 4, half-maximal inhibitory concentration: 1350 nM
Estimate against measurement, compound 4: 1.1-fold (0.05 log units) above; the measured number falls inside the stated range.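

In this assay, the change from phenyl to 4-methylphenyl moves the number in the same direction on both cores: the same change on two cores in this assay, an at least 2.5-fold higher number (0.40 log units; beyond the scatter) from compound 1 to compound 2 and a 4.4-fold higher number (0.64 log units; beyond the scatter) from compound 3 to compound 4; the limit leaves it open whether they differ. Within the data shown here, the only step with a full size is a 4.4-fold higher number from compound 3 to compound 4 (0.64 log units; beyond the scatter), while the exchange of the other group on the 4-methylphenyl compounds gives an at least 37-fold lower number from compound 2 to compound 4 (1.56 log units; beyond the scatter). Two cores show a shared direction but not a transferable size, and compound 2 stands at a limit: the limit of > 50000 nM in this assay, at which 1 of the 4 values shown sits.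

Still open, from the compounds shown here alone, is whether other groups at the same place on the ring, such as chloro, methoxy or a carboxylic acid, would follow methyl. Also open, going by these compounds, is whether a piperidin-1-yl without the hydroxy group would keep the low number of compound 3.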